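The source may report more compounds than this note shows. Statements on the series, on what has been measured and on what is new or still open speak of the compounds shown alone.

Three compounds sharing one core have been examined in an ADME assay on microsomes from liver (Rattus norvegicus) for metabolic stability; on this read-out lower numbers stand for a shorter-lived compound and higher numbers for a longer-lived compound. Compound 1 `CC(C)NC(=O)CC(c1ccc(-c2ccc3cccc(F)c3c2)[nH]c1=O)C(C)C` sits at a limit of the assay, giving < 0.0667 h. Compound 2 `CC(C)C(c1noc(=O)[nH]1)c1ccc(-c2ccc3cccc(F)c3c2)[nH]c1=O` also sits at a limit of the assay, giving > 3 h. Compound 3 `CC(C)C(c1ncco1)c1ccc(-c2ccc3cccc(F)c3c2)[nH]c1=O` is the only one of the three with a number rather than a limit, giving 0.0983 h in this assay. Compound 4 `CC(C)C(Cc1noc(=O)[nH]1)c1ccc(-c2ccc3cccc(F)c3c2)[nH]c1=O` has not yet been measured. It differs from compound 3 in one place: a group of 7 heavy atoms (3 carbon, 2 nitrogen, 2 oxygen; one five-membered aromatic ring with 3 hetero atoms) in place of a group of 5 heavy atoms (3 carbon, 1 nitrogen, 1 oxygen; one five-membered aromatic ring with 2 hetero atoms), on a saturated chain carbon bound to an aromatic carbon and a saturated chain carbon. The group that enters contains the five-membered aromatic ring with 3 hetero atoms that compound 2 carries. For the measured compounds named here, two measured steps bear on this change: an at least 30-fold lower number from compound 2 to compound 3 (1.48 log units; beyond the scatter), and an at least 44-fold higher number from compound 1 to compound 2 (1.65 log units; beyond the scatter). Both are large, and in both the ring with 3 hetero atoms stands on the longer-lived side. A large rise is therefore expected for compound 4, with a real chance that this assay again reports only a limit. The expected step is a 20-fold higher number from compound 3 to compound 4 (1.31 log units; beyond the scatter). For compound 4 the estimate in this assay is 2 h, within 0.5 h to 6 h.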

Compound 4, half-life: > 3 h
Compound 4: a limit, no number; the forecaster's own chance of this, stated with the estimate: 40%; middle value at least 1.5-fold (0.17 log units) from the limit.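

In this assay, the longer group in compound 4 carries the same five-membered aromatic ring with 3 hetero atoms as compound 2, and the change still gives an at least 30-fold higher number from compound 3 to compound 4 (1.48 log units; beyond the scatter). A second comparison isolates the ring at the saturated chain carbon two bonds along the chain from an aromatic carbon: putting it in place of the open-chain group of compound 1 gives an at least 44-fold higher number from compound 1 to compound 4 (1.65 log units; beyond the scatter), so the rise does not depend on the shorter attachment found in compound 2. Compound 2 and compound 4, the two compounds with this ring, both stand at an assay limit rather than at a number: the limit of > 3 h in this assay, at which 2 of the 4 values shown sit.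

The step from compound 2 to compound 4 cannot be read, so any difference between these two attachments stays hidden. As far as these compounds go, it also remains open whether a carboxylic acid in place of the ring, or a longer chain carrying it, would give a similarly long half-life.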